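Compound 3 to compound 4: fluoro for bromo

The source may report more compounds than this note shows. Statements on the series, on what has been measured and on what is new or still open speak of the compounds shown alone.

Among the measured compounds shown here, in a functional assay on KYSE-410 cells (Homo sapiens) for antiproliferative activity, read by MTT assay, with a stated time of 72 h (a lower number here means a stronger inhibitor, a higher number a weaker inhibitor), compound 3 `O=C(Nc1cc(F)cc(F)c1)c1cc(=O)[nH]c2cc(Br)ccc12` gives 11200 nM as the only actual number so far. Compound 1 `O=C(c1ccnc2cc(Br)ccc12)N1CCCCC1` reads > 20000 nM which is a limit. Compound 2 `O=C(Nc1cc(F)c(F)c(F)c1)c1cc(=O)[nH]c2cc(Br)ccc12` reads > 20000 nM which is also a limit. Compound 4 `O=C(Nc1cc(F)cc(F)c1)c1cc(=O)[nH]c2cc(F)ccc12` differs from compound 3 by fluoro in place of bromo on an aromatic carbon in the shared core: fluoro in place of bromo on an aromatic carbon. For the measured compounds named here, the only measured step is an at least 1.7-fold lower number from compound 2 to compound 3 (0.25 log units; that floor lies within the scatter) and it concerns a fluoro, not the bromo, so it gives no direct guide. Compound 4 may also end at a limit, given the limit of > 20000 nM in this assay, at which 2 of the 3 values shown sit, in this small set. No shift beyond the scatter is expected, the estimated step being a 1.3-fold higher number from compound 3 to compound 4 (0.10 log units; within the scatter) from the anchor value. The estimate for compound 4 is 14000 nM with 6000 nM to 30000 nM as the expected range.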

Compound 4, half-maximal inhibitory concentration: > 20000 nM
Compound 4: no number, only a limit; the forecaster's own chance of this, stated with the estimate: 35%; middle value at least 1.4-fold (0.15 log units) from the limit.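

In this assay, compound 4 gives > 20000 nM which is a limit and not a number. This is the only change shown at the bromo position of the shared core: the step is an at least 1.7-fold higher number from compound 3 to compound 4 (0.25 log units; that floor lies within the scatter) and gives only a floor, so fluoro brings no measurable gain there and the size of any loss stays unknown. Compound 3 remains the only compound with a number, and the others sit at one limit: the limit of > 20000 nM in this assay, at which 3 of the 4 values shown sit.

Going by these compounds, it remains open whether a methoxy or an amine at this position would give a lower number than compound 3 at 11200 nM in this series. The limit also leaves the true value of compound 4 unresolved.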